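The compounds below may be only part of what the source reports. "The series", "measured", "known", "first", "only" and "open" are said of these compounds alone.

Compound 1 `COc1ccc(Cn2c(C(N)=O)cc3sccc32)cc1` in an ADME assay on HEK-293T cells (Homo sapiens) for cytotoxicity, read by luminescence, with a stated time of 24 h (a lower number here means that less compound is tolerated, a higher number that more compound is tolerated), gives > 100000 nM, which is a limit of the assay and not a number. Compound 3 `CCN(CC)C(=O)c1cc2sccc2n1Cc1ccc(OC)cc1` in this assay gives > 100000 nM, again a limit. Compound 2 `COc1ccc(Cn2c(C(=O)NC(C)c3ccccc3)cc3sccc32)cc1` in this assay gives > 100000 nM, also a limit, so that the limit of > 100000 nM in this assay, at which 3 of the 3 values shown sit, describes the whole measured set. Compound 4 `COc1ccc(Cn2c(C(=O)N3CCC(C(N)=O)CC3)cc3sccc32)cc1` is not yet measured; its change from compound 2 is 4-carbamoylpiperidin-1-yl in place of (1-phenylethyl)amino on a carbonyl carbon. Among the compounds with values here, the steps that bear on it, a step that the two limits leave unreadable from compound 2 to compound 3, a step that the two limits leave unreadable from compound 1 to compound 2 and a step that the two limits leave unreadable from compound 1 to compound 3, each sit between two limits, so none shows a readable size or direction. No step beyond the scatter is therefore expected, and compound 4 is expected to stay at the limit, a step that the limit leaves unreadable from compound 2 to compound 4. Compound 4 is estimated at 150000 nM, with a range from 50000 nM to 500000 nM.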

Compound 4, half-maximal cytotoxic concentration: > 100000 nM
Compound 4 was reported as a limit; the forecaster's own chance of this, stated with the estimate: 85%; the middle value does not contradict the limit.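

Steps from compound 1, compound 2 and compound 3 to compound 4 cannot be read, as all four compounds share one assay limit: the limit of > 100000 nM in this assay, at which 4 of the 4 values shown sit.

The compounds shown leave open whether any replacement on the carbonyl carbon changes tolerance in this assay.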